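The source may report more compounds than this note shows. Statements on the series, on what has been measured and on what is new or still open speak of the compounds shown alone.

Measured compounds:
compound 2 `C=C[C@@](C)(/C=C/c1ccc(O)c(CO)c1)CCC=C(C)C`: > 49000 nM
compound 1 `C=C[C@@](C)(/C=C/c1ccc(O)cc1)CC/C=C/C(=O)OCC`: > 49000 nM

In a functional assay on Jurkat cells (Homo sapiens) for cytotoxicity, with a stated time of 72 h (a lower number here means that less compound is needed, a higher number that more compound is needed for the effect), compound 2 gives > 49000 nM, a limit of the assay rather than a number. In this assay compound 1 likewise gives > 49000 nM, also a limit. Among the measured compounds shown here, both values therefore sit at the limit of > 49000 nM in this assay, at which 2 of the 2 values shown sit, so no measured step between them exists, and compound 2 cannot be placed above or below any other compound on what is known.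

Compound 3 `C=C[C@@](C)(/C=C/c1ccc(O)c(/C=C/c2ccc(F)cc2)c1)CCC=C(C)C` has not yet been measured. It differs from compound 2 in one place: 2-(4-fluorophenyl)ethenyl in place of hydroxymethyl on an aromatic carbon. A much larger group thus replaces a small one on the same aromatic carbon, next to the hydroxy group named in that difference.

With both known values at the limit, the expected step from compound 2 to compound 3 in this assay is toward lower numbers, an at least 1.9-fold lower number from compound 2 to compound 3 (0.29 log units; that floor lies within the scatter), though a further limit remains likely. Compound 3 is expected to give about 25000 nM, in the range 5000 nM to 49000 nM.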

Compound 3, half-maximal effective concentration: > 49000 nM
Compound 3: a limit, no number; the forecaster's own chance of this, stated with the estimate: 55%; middle value at least 1.9-fold (0.29 log units) from the limit.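

In this assay compound 3 gives > 49000 nM as a limit of the assay, not a number, so no step can be read between compound 2 and compound 3. How 2-(4-fluorophenyl)ethenyl and hydroxymethyl compare in this assay stays open, as does any ranking of the compounds shown.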